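Three flat analogues and a heteroaryl replacement awaiting measurement

A few compounds are considered here, and "the series" means these few. Any claim that something is new, unique, unknown or untested is made for them only; others in the source may bear on it.

Compound 1 `CC(C)(C)Cc1c(-c2ccc(F)cc2F)sc(N)c1C(=O)c1ccc(Cl)cc1`: 1%
Compound 2 `CC(C)(C)Cc1c(-c2cc(F)ccc2F)sc(N)c1C(=O)c1ccc(Cl)cc1`: 3%
Compound 3 `Cc1ccccc1-c1sc(N)c(C(=O)c2ccc(Cl)cc2)c1CC(C)(C)C`: 1%

In an assay on CHO cells for displacement of a labelled ligand from adenosine receptor A1 (Homo sapiens), read by scintillation counting, tested at 10 uM (on this read-out lower numbers stand for less inhibition and higher numbers for more inhibition at the one concentration tested (going by the name of the read-out)), compound 1 gives 1%, compound 2 gives 3% and compound 3 gives 1%. The three numbers sit close together: no change at the digits printed from compound 1 to compound 3 (within the scatter), and a number 2 percentage points lower from compound 2 to compound 3 (within the scatter), so compound 3 stands level with compound 1 and only a little apart from compound 2, none of it beyond the scatter.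

Compound 4 `Cc1noc(C)c1-c1sc(N)c(C(=O)c2ccc(Cl)cc2)c1CC(C)(C)C` is the next analogue. Relative to compound 3 the change is 3,5-dimethyl-1,2-oxazol-4-yl in place of 2-methylphenyl on an aromatic carbon.

The three measured steps all exchange the aromatic group at this same position, and all stayed within the scatter: a number 2 percentage points higher from compound 1 to compound 2 (within the scatter), no change at the digits printed from compound 1 to compound 3 (within the scatter) and a number 2 percentage points lower from compound 2 to compound 3 (within the scatter). Among the measured compounds shown here, no measured step involves a five-membered heteroaromatic group, so the move to compound 4 goes somewhat beyond what has been tested. Still, given that every exchange so far left the read-out unmoved, the expected step of a number 1 percentage points higher from compound 3 to compound 4 (within the scatter) is no change beyond the scatter. Compound 4 is therefore estimated at 2%, with a range from -8% to 12%.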

Compound 4, a percentage reported as inhibition, at one concentration (the size of the read-out at that concentration, not a potency): 1%
For compound 4 the middle estimate is 1 percentage points above the measured one; the range from low to high includes it.
By their numbers in this assay, from the lowest: compounds 1, 3, 4 and 2 (each within the scatter of the next).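

Compound 4 brings the first five-membered aromatic ring with 2 hetero atoms to this position, and the exchange reads the same as those among the six-membered carbon rings: no change at the digits printed from compound 3 to compound 4 (within the scatter) and no change at the digits printed from compound 1 to compound 4 (within the scatter) and a number 2 percentage points lower from compound 2 to compound 4 (within the scatter) in this assay. At equal size of 7 heavy atoms, replacing carbon with nitrogen and oxygen in the ring and adding 2 hydrogen-bond acceptors therefore leaves the read-out within the scatter across these four compounds. Nothing in the material shown offers an explanation for this flat result.

From the compounds shown here alone, it remains open whether a non-aromatic group at this position, such as a carboxylic acid or an aminomethyl group, would shift the read-out. Going by these compounds, the neopentyl group and the (4-chlorophenyl)carbonyl group are the same in all four compounds, so their part in the read-out also remains open.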